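This account rests on a few compounds, and the source may have more. Where it says the series, first, only, none or still open, it means among the compounds named here.

Measured compounds in a functional assay for agonist activity at Free fatty acid receptor 1 (Homo sapiens), read by FLIPR, in the presence of a further agent that is not named here; on this read-out higher numbers stand for an effect only at larger amounts of compound and lower numbers for an effect already at smaller amounts:
compound 1 `O=C1NC(=O)C(Cc2ccc(Oc3ccc(C(F)(F)F)cc3Cl)cc2)S1`, 78 nM
compound 2 `Cc1cccnc1Oc1ccc(CC2SC(=O)NC2=O)cc1`, 1090 nM
compound 3 `O=C1NC(=O)C(Cc2ccc(Oc3cccc(C(F)(F)F)n3)cc2)S1`, 1640 nM

Compound 1 gives the lowest number of the three measured compounds; compound 2 and compound 3 both sit well higher, and each of those gaps lies beyond the usual scatter. Compound 4 `Cc1cc(Oc2ccc(C(F)(F)F)cc2Cl)ccc1CC1SC(=O)NC1=O` keeps the core of compound 1 and differs from it in a single place: methyl in place of hydrogen on an aromatic carbon. For the measured compounds named here, no measured pair shows the effect of this change, so its size is unknown from the data. Going by the values given here, with only three measured compounds and no comparable step, a step of modest size, in either direction or none beyond the scatter, is expected in this assay. Compound 4 is expected to give 100 nM, within a range from 30 nM to 330 nM. The expected step of a 1.3-fold higher number from compound 1 to compound 4 (0.11 log units; within the scatter) is accordingly small.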

Compound 4, half-maximal effective concentration: 18 nM
Beside the measured number, compound 4's estimate is 5.6-fold (0.74 log units) above it, outside the stated range (below it).
By their numbers in this assay, from the lowest: compound 4; then compound 1; then compounds 2 and 3 (each within the scatter of the next).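

Methyl in place of hydrogen on the aromatic carbon ortho to the (2,4-dioxo-1,3-thiazolidin-5-yl)methyl group gives in this assay a 4.3-fold lower number from compound 1 to compound 4 (0.64 log units; beyond the scatter) and so counts as a modest gain. For the compounds shown here, compounds 1, 2 and 3 all carry hydrogen at this carbon, so only this pair shows that the position accepts a substituent and that the number falls with it. No measurement at hand accounts for the step.

From the compounds shown here alone, whether ethyl, methoxy or fluorine at this carbon would do the same remains open. Also open, going by these compounds, is whether methyl here would lower the number for compound 2 or compound 3.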